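Group of 3 heavy atoms replacing methylsulfanyl on two cores

This account rests on a few compounds, and the source may have more. Where it says the series, first, only, none or still open, it means among the compounds named here.

Measured compounds:
compound 1, `CSc1nnc(-c2ccc(C)cc2)n1C`, gives > 100 mg/kg, a limit of the assay.
compound 2, `Cc1ccc(-c2nnc([S+](C)[O-])n2C)cc1`, gives > 200 mg/kg, a limit of the assay.
compound 3, `CSc1nc(-c2ccccc2)n(C)n1`, gives > 100 mg/kg, a limit of the assay.

All three values come from a functional assay on the whole organism for antagonist activity, with Mus musculus as the target, in the maximal electroshock model; on this read-out lower numbers stand for an effect already at smaller amounts and higher numbers for an effect only at larger amounts of compound. In this assay compound 1 reaches only the limit > 100 mg/kg. Compound 2 likewise reaches only the limit > 200 mg/kg. The change between them is a group of 3 heavy atoms (1 carbon, 1 oxygen, 1 sulfur; no ring) in place of a group of 2 heavy atoms (1 carbon, 1 sulfur; no ring), on an aromatic carbon, and the step that the two limits leave unreadable from compound 1 to compound 2 cannot be sized, since both ends sit at limits: the limit of > 100 mg/kg in this assay, at which 2 of the 3 values shown sit, and (the limit of > 200 mg/kg in this assay, at which 1 of the 3 values shown sits). How the core of compound 1 and the core of compound 3 differ is not broken down here.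

Compound 4, `Cn1nc([S+](C)[O-])nc1-c1ccccc1`, is not yet measured. It differs from compound 3 by a group of 3 heavy atoms (1 carbon, 1 oxygen, 1 sulfur; no ring) in place of a group of 2 heavy atoms (1 carbon, 1 sulfur; no ring), on an aromatic carbon. This is the same kind of change as that from compound 1 to compound 2, but the surroundings of the place are not identical: in compound 1 the changed carbon is next to the ring atom that bears a methyl group, whereas in compound 3 it is two ring bonds from the ring atom that bears a methyl group.

Compound 3 itself stands only at a limit, > 100 mg/kg, so the step for compound 4 is expected to stay unreadable as well, an estimated step that the limit leaves unreadable from compound 3 to compound 4 resting on the unreadable earlier step. For compound 4 the expected value is 150 mg/kg, with an estimated range from 80 mg/kg to 400 mg/kg, most likely reported again as a limit.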

Compound 4, dose for half-maximal effect: > 200 mg/kg
Compound 4 ended at the assay's limit (the forecaster's own chance of this, stated with the estimate: 85%); middle value at least 1.3-fold (0.12 log units) away from the limit.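

Going by these compounds alone, compound 3 and compound 4 both stand only at limits in this assay, and no step between them can be read. The compounds shown leave open whether the group of 3 heavy atoms in place of methylsulfanyl changes the dose for half-maximal effect on either core, and what actual value compound 1, compound 2, compound 3 or compound 4 has.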